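The compounds below may be only part of what the source reports. "The series", "measured", "known", "first", "only" and "open" are said of these compounds alone.

For the measured compounds named here, compound 2, whose structure is `CC(C)C[C@H](N)CN(C(=O)[C@@H]1C[C@H]1c1ccccc1)c1ccc(C2=CCCC2)cc1`, is one of two compounds measured so far in a functional assay for agonist activity at G protein-coupled receptor 88 (Homo sapiens), read by HTRF and cAMP accumulation (a lower number here means that less compound is needed, a higher number that more compound is needed for the effect), where compound 2 gives 1200 nM. Its companion compound 1, `CC[C@H](C)[C@H](N)CN(C(=O)[C@@H]1C[C@H]1c1ncc(C)s1)c1ccc(-c2ccccc2)cc1`, gives 1300 nM in this assay, and the two numbers lie within the scatter of each other, so neither stands apart. Compound 3, `CC(C)C[C@H](N)CN(C(=O)[C@@H]1C[C@H]1c1ccccc1)c1ccc(-c2ccccc2Cl)cc1`, has not yet been measured. It differs from compound 2 by 2-chlorophenyl in place of cyclopent-1-en-1-yl on an aromatic carbon. Going by the values given here, with no measured step to draw on, the account expects a change no larger than the scatter, in either direction, and it estimates a 1.2-fold lower number from compound 2 to compound 3 (0.08 log units; within the scatter). Compound 3 is therefore expected to give about 1000 nM, with a range from 300 nM to 3500 nM.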

Compound 3, half-maximal effective concentration: 3800 nM
Estimate against measurement, compound 3: 3.8-fold (0.58 log units) below, outside the stated range (above it).
By their numbers in this assay, from the lowest: compounds 2 and 1 (each within the scatter of the next); then compound 3.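

At this place, on an aromatic carbon para to a large group, the choice of substituent registers in this assay: 2-chlorophenyl in place of cyclopent-1-en-1-yl gives a 3.2-fold higher number from compound 2 to compound 3 (0.50 log units; beyond the scatter). Compound 1 and compound 2 differ in more than one place, so they could not show this for a single change. Nothing measured here accounts for the step.

On these data alone, it remains open whether the chlorine or the change of ring carries the step. An unsubstituted phenyl group at this place, with everything else as in compound 2, would separate the two.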